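Removing a Bromine from Two Related Cores

The source may hold more compounds than are shown below. What is called first, only, known or untested is meant among the compounds shown, and "the series" means these compounds.

Compound 1, `Cc1ccc2nc(/N=C3\C(=O)N(CN(C)C)c4cccc(Br)c43)sc2c1`, in a functional assay on MDA-MB-231 cells (Homo sapiens) for cytotoxicity, read by sulforhodamine B assay, with a stated time of 48 h; on this read-out lower numbers stand for stronger inhibition of growth and higher numbers for weaker inhibition of growth: 49000 nM
Compound 2, `CN(C)CN1C(=O)C(=O)c2c(Br)cccc21`, in this assay: 93700 nM
Compound 3, `Cc1ccc2nc(/N=C3\C(=O)N(CN(C)C)c4ccccc43)sc2c1`, in this assay: 19200 nM

Compound 1 and compound 3 share one core and differ only in hydrogen in place of bromo on an aromatic carbon. In this assay that change gave a 2.6-fold lower number from compound 1 to compound 3 (0.41 log units; beyond the scatter), a modest gain in growth inhibition. Compound 2 is built on a different core; the difference between the two cores is not broken down here. Its number lies nearest to that of compound 1 and furthest from that of compound 3.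

Compound 4, `CN(C)CN1C(=O)C(=O)c2ccccc21`, has not been measured. It stands to compound 2 as compound 3 stands to compound 1: hydrogen in place of bromo on an aromatic carbon. The two place descriptions agree word for word, so this is the same change made on the second core. The one measured case of this change gave a 2.6-fold lower number from compound 1 to compound 3 (0.41 log units; beyond the scatter), and since it rests on a single pair only, a step of similar size is expected for compound 4, a 2.3-fold lower number from compound 2 to compound 4 (0.37 log units; beyond the scatter). Compound 4 is therefore estimated at 40000 nM, with a likely range from 15000 nM to 110000 nM.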

Compound 4, concentration for 50% growth inhibition: 65600 nM
Estimate against measurement, compound 4: 1.6-fold (0.21 log units) below; measured number inside the range.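

Made on the core of compound 2, the change from bromo to hydrogen gave a 1.4-fold lower number from compound 2 to compound 4 (0.15 log units; within the scatter), a step that on its own cannot be told apart from the ordinary variation between repeated measurements. Set beside the earlier step, the two steps in this assay do not differ by more than such variation allows: the same change on two cores in this assay, a 2.6-fold lower number (0.41 log units; beyond the scatter) from compound 1 to compound 3 and a 1.4-fold lower number (0.15 log units; within the scatter) from compound 2 to compound 4, 1.8-fold (0.25 log units) apart, within the scatter of two such steps

Within these two pairs, then, the change carries over from one core to the other without a detectable difference in size, but two pairs cannot show that the step has one fixed size, nor that it would hold on any further core.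

The compounds shown carry only bromo or hydrogen at this place on the aromatic ring, so what a chlorine, a methoxy group or a nitrile would do there remains open. Also open, as far as these compounds go, is whether the same change would give a similar step with a morpholine in place of the dimethylamino group.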